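Extending the Amino Group on an Inactive Core

The source may hold more compounds than are shown below. What is called first, only, known or untested is meant among the compounds shown, and "the series" means these compounds.

Compound 1 `COc1ccc(-c2c(C)nc3c(N)cc(Cl)nn23)cc1OC`: in an assay on isolated protein for inhibition of phosphatidylinositol 4-kinase type 2-alpha (Homo sapiens), read by ADP-Glo, with a stated time of 60 min (a lower number here means a stronger inhibitor, a higher number a weaker inhibitor), compound 1 gives only a limit, > 100000 nM.
Compound 2 `COc1ccc(-c2c(C)nn3c(NCCNC(=O)C(C)C)cc(C)nc23)cc1OC`: in this assay compound 2 gives only a limit, > 100000 nM.
Compound 3 `CC(=O)NCCNc1cc(Cl)nn2c(-c3cccc(S(=O)(=O)NC(C)C)c3)c(C)nc12`: in this assay compound 3 gives only a limit, > 100000 nM.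

Compound 1 stands where every measured compound here stands: at the limit of > 100000 nM in this assay, at which 3 of the 3 values shown sit. No number is known for it, only that it lies past the limit of this assay. Nothing among the three values separates any compound from another.

The unmeasured compound 4 `COc1ccc(-c2c(C)nc3c(NCCNC(C)=O)cc(Cl)nn23)cc1OC` differs from compound 1 in a single place: 2-acetamidoethyl in place of hydrogen on a nitrogen on an aromatic ring. Compound 3 carries a (2-acetamidoethyl)amino group of the same kind on its core, and compound 3 also sits at the limit, so this extension alone has not brought any measured compound into the readable range.

With all values at the limit, no step size can be read from the data. The step from compound 1 to compound 4 is expected to be a step that the limit leaves unreadable from compound 1 to compound 4, none beyond the scatter, and compound 4 is expected to return only a limit again. The estimate for compound 4 is 150000 nM, with a range from 30000 nM to 1000000 nM.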

Compound 4, half-maximal inhibitory concentration: > 100000 nM
Compound 4 was reported as a limit (the forecaster's own chance of this, stated with the estimate: 85%); the middle value is on the limit's open side.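

For the compounds shown here, compound 1 and compound 4 both return only a limit, so no step between them can be read: the limit of > 100000 nM in this assay, at which 4 of the 4 values shown sit.

The compounds shown leave open how far past that limit each one lies, and whether any change to these structures can bring a value into the readable range of this assay at all.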